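Adding a methyl to the chlorophenyl ring of compound 2

This account rests on a few compounds, and the source may have more. Where it says the series, first, only, none or still open, it means among the compounds named here.

Of the compounds shown here, three share one core and have been measured in a physicochemical assay for lipophilicity, in phosphate buffer, measured as octanol-water partition; a lower number here means a more polar compound, a higher number a more lipophilic compound. Compound 1 `O=c1c2ccccc2nc(-c2ccccc2)n1/N=C/c1ccc(Oc2ccc3ccccc3c2)cc1` gives 6.53 in this assay. Compound 3 `O=c1c2ccccc2nc(-c2ccccc2)n1/N=C/c1ccc(Oc2ccc(Cl)cc2)cc1` gives 6.38, and the change of ring on the oxygen gives a number 0.15 log units lower from compound 1 to compound 3 (within the scatter). Compound 2 `CCCc1nc2ccccc2c(=O)n1/N=C/c1ccc(Oc2ccc(Cl)cc2)cc1` gives 5.78, the lowest of the three numbers; exchanging its propyl for a phenyl gives a number 0.60 log units higher from compound 2 to compound 3 (beyond the scatter).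

Compound 4 `CCCc1nc2ccccc2c(=O)n1/N=C/c1ccc(Oc2ccc(Cl)c(C)c2)cc1` is not yet measured. It differs from compound 2 in one place: methyl in place of hydrogen on an aromatic carbon. Going by the values given here, neither measured step involves a methyl, so no step bears directly on this change; both concern larger groups elsewhere on the molecule. What can be said is that one carbon enters with no donors or acceptors, a small change compared with the measured steps. The expectation for compound 4 in this assay is a modest rise, a number 0.42 log units higher from compound 2 to compound 4 (beyond the scatter), above compound 2. Compound 4 is therefore estimated at 6.2, with a range from 5.85 to 6.55.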

Compound 4, partition coefficient: 6.02
Compound 4: middle estimate off by 0.18 log units, on the high side; low and high end bracket the measured number.
By their numbers in this assay, from the lowest: compounds 2 and 4 (each within the scatter of the next); then compounds 3 and 1 (each within the scatter of the next).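

In this assay, methyl in place of hydrogen, on the aromatic carbon ortho to a chloro group, gives a number 0.24 log units higher from compound 2 to compound 4 (within the scatter), so the two compounds cannot be told apart by this measurement. At this carbon, then, one added methyl does not shift the number by more than repeated measurements would, whereas phenyl in place of propyl elsewhere on the molecule does, giving a number 0.60 log units higher from compound 2 to compound 3 (beyond the scatter). Nothing available explains the size of the methyl step.

On these data alone, whether a different group on this same carbon, such as an amine, a carboxylic acid or a longer chain, would move the number beyond the scatter remains open. Also open, as far as these compounds go, is whether the same methyl would give a similar step on compound 3, which carries phenyl in place of propyl.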